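A few compounds are considered here, and "the series" means these few. Any claim that something is new, unique, unknown or untested is made for them only; others in the source may bear on it.

Measured so far in an ADME assay on microsomes from liver (Homo sapiens) for metabolic stability, with a stated time of 10 min; a higher number here means that more of the compound is left, a lower number that less of the compound is left:
- compound 1 `Cc1c(Cl)cccc1Oc1cccn2c(C34CCC(N)(CC3)CC4)nnc12`: "not determined" (no result reported)
- compound 2 `Cc1c(Cl)cccc1Oc1cccn2c(C3CCCCCC3O)nnc12`: 81%

Among the compounds with values here, compound 1 has no number in this assay, so it offers no baseline for a step. Compound 3 `COC12CCC(c3nnc4c(Oc5cccc(Cl)c5C)cccn34)(CC1)CC2` has no result yet. The structural change is methoxy in place of amino on a saturated ring carbon. No direction or size of step can be expected from compound 1, and no step beyond the scatter is assumed. Within the data shown here, the only anchor is compound 2 at 81%, so the expectation stays moderately high but uncertain. Compound 3 is expected at 70%, with an estimated range of 45% to 90%.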

Compound 3, percent of the compound remaining: 87%
For compound 3 the middle estimate is 17 percentage points below the measured one; the measured number falls inside the stated range.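

In this assay, within the data shown here, compound 1 reads "not determined" (no result reported) and compound 3 reads 87%, so no step between compound 1 and compound 3 can be read. The compounds shown leave open how methoxy compares with amino on that saturated ring carbon. No measured property on hand bears on the result.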